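This account rests on a few compounds, and the source may have more. Where it says the series, first, only, none or still open, it means among the compounds named here.

Measured so far in a functional assay on MDA-MB-231 cells (Homo sapiens) for inhibition, read by CCK-8 assay, with a stated time of 48 h; a lower number here means a stronger inhibitor of growth, a higher number a weaker inhibitor of growth:
- compound 1 `CN1CCN(c2ccc(Nc3ncc(Cl)c(Nc4ccccc4)n3)nc2)CC1`: 37400 nM
- compound 2 `CC(C)c1ccc(Nc2nc(Nc3ccc(N4CCN(C)CC4)cn3)ncc2Cl)cc1`: 7020 nM

Of these two compounds, compound 2 has the lower number and is therefore the stronger inhibitor of growth, with 7020 nM. The next compound, compound 3 `CC(C)c1ccccc1Nc1nc(Nc2ccc(N3CCN(C)CC3)cn2)ncc1Cl`, contains the same atoms as compound 2, joined differently: 2-isopropylphenyl in place of 4-isopropylphenyl on a nitrogen on an aromatic ring. In words, 2-isopropylphenyl stands in place of 4-isopropylphenyl on a nitrogen on an aromatic ring.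

Going by the values given here, only one measured step bears on this change: a 5.3-fold lower number from compound 1 to compound 2 (0.73 log units; beyond the scatter), with isopropyl in place of hydrogen on an aromatic carbon. Among the compounds with values here, that step shows what adding the group did, but no measured pair shows what moving it does. Compound 3 keeps the isopropyl, so a change as large as that step is not expected. A small move towards a higher number in this assay seems most likely, possibly no larger than the scatter. The estimated step is a 1.4-fold higher number from compound 2 to compound 3 (0.15 log units; within the scatter). For compound 3, the expected value is 10000 nM, with an estimated range of 3500 nM to 30000 nM.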

Compound 3, concentration for 50% growth inhibition: 4090 nM
Compound 3: middle estimate off by 2.4-fold (0.39 log units), on the high side; low and high end bracket the measured number.
By their numbers in this assay, from the lowest: compounds 3 and 2 (each within the scatter of the next); then compound 1.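

In this assay, moving the isopropyl group so that 2-isopropylphenyl replaces 4-isopropylphenyl on the same nitrogen gives a step within the scatter (a 1.7-fold lower number from compound 2 to compound 3 (0.23 log units; within the scatter)), so these two placements cannot be told apart here. Compared with the unsubstituted phenyl of compound 1, the 2-isopropylphenyl group also gives a step beyond the scatter (a 9.1-fold lower number from compound 1 to compound 3 (0.96 log units; beyond the scatter)), as the 4-isopropylphenyl group does (a 5.3-fold lower number from compound 1 to compound 2 (0.73 log units; beyond the scatter)), so the link between adding isopropyl and a lower number is now seen at two placements rather than one. No measured evidence here explains why the placement makes so little difference in this pair.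

These compounds leave open whether the isopropyl group itself matters or whether a smaller or different group would serve as well, such as the methyl of 2-methylphenyl or the amine of 2-aminophenyl on the same nitrogen. They also leave open whether 3-isopropylphenyl would fit the same picture, since only two placements of the group are shown.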